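Methoxy for Methyl on the Aryl Ring: Cytotoxicity Outlook

The source may hold more compounds than are shown below. What is called first, only, known or untested is meant among the compounds shown, and "the series" means these compounds.

In an ADME assay on Vero cells (Chlorocebus sabaeus) for cytotoxicity, with a stated time of 72 h, tested at 10 ug/mL (a higher number here means a stronger effect of the compound at the concentration tested, a lower number a weaker effect), compound 1 `O=c1[nH]nc2n(c1=O)CCN2c1ccccc1` gives 7%, compound 2 `Cc1ccc(N2CCn3c2n[nH]c(=O)c3=O)cc1` gives 0%, and compound 3 `COc1ccc(N2CCN/C2=N\N)cc1`, built on a different core, gives 0%. Compound 2 thus stands level with compound 3, the two sharing the lowest numbers shown, and the step of a number 7 percentage points lower from compound 1 to compound 2 (within the scatter) shows that a methyl at that position left the read-out essentially unchanged. Compound 4 `COc1ccc(N2CCn3c2n[nH]c(=O)c3=O)cc1` differs from compound 2 in one place: methoxy in place of methyl on an aromatic carbon. Among the measured compounds shown here, only the step from compound 1 to compound 2 concerns this position, and it lay within the scatter; compound 3, which also bears a methoxy, gives a read-out matching compound 2. A step of a number 2 percentage points higher from compound 2 to compound 4 (within the scatter) is therefore expected, nothing beyond the scatter. Compound 4 is estimated at 2%, between -6% and 12%.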

Compound 4, a percentage reported as inhibition, at one concentration (the size of the read-out at that concentration, not a potency): 0%
For compound 4 the middle estimate is 2 percentage points above the measured one; low and high end bracket the measured number.
By their numbers in this assay, from the lowest: compounds 2, 3, 4 and 1 (each within the scatter of the next).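

In this assay, methoxy in place of methyl gives no change at the digits printed from compound 2 to compound 4 (within the scatter) and methoxy in place of hydrogen gives a number 7 percentage points lower from compound 1 to compound 4 (within the scatter) on the same aromatic carbon, para to a large group. Hydrogen, methyl and methoxy at this position, the last bringing one hydrogen-bond acceptor, therefore all sit within the scatter of one another. No supporting data explain this flat picture.

Going by these compounds, whether an amine or a carboxylic acid at this position would move the read-out beyond the scatter remains open.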